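Aryl exchange on the amide-type nitrogen: compound 1 to 4

The compounds below may be only part of what the source reports. "The series", "measured", "known", "first", "only" and "open" are said of these compounds alone.

Compound 1 `COc1ccccc1NC(=S)N/N=C/c1ccc2ccccc2n1` gives 91700 nM in a functional assay on HL-60 cells (Homo sapiens) for antiproliferative activity, read by sulforhodamine B assay, with a stated time of 72 h (a higher number here means a weaker inhibitor, a lower number a stronger inhibitor), the higher of the two numbers measured, with compound 3 `CN(C)C(=S)N/N=C/c1ccc2cccnc2n1` giving 560 nM. Compound 2 `COc1ccc(C)cc1NC(=S)N/N=C/c1ccc2ccccc2n1` reaches only the limit > 100000 nM in this assay. Among the compounds with values here, the single step measured in one place, an at least 1.0-fold higher number from compound 1 to compound 2 (0.03 log units; that floor lies within the scatter), runs into the limit of > 100000 nM in this assay, at which 1 of the 3 values shown sits, and so sets only a floor. Within the data shown here, the change to compound 4 `N#Cc1ccc(NC(=S)N/N=C/c2ccc3ccccc3n2)cc1`, (4-cyanophenyl in place of 2-methoxyphenyl on an amide-type nitrogen), has no measured counterpart; the aryl group on that nitrogen has been varied only by the step to compound 2, which sat within the scatter. The expected step in this assay is therefore small, a 1.3-fold lower number from compound 1 to compound 4 (0.12 log units; within the scatter), with no firm direction. Compound 4 is estimated at 70000 nM, range 20000 nM to 150000 nM.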

Compound 4, half-maximal inhibitory concentration: 4660 nM
Compound 4: middle estimate off by 15-fold (1.18 log units), on the high side; the measured number lies below the stated range.
By their numbers in this assay, from the lowest: compound 3; then compound 4; then compound 1. At a limit, above all of these: compound 2.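

Within the data shown here, the aryl group on this amide-type nitrogen is not a silent position in this assay: 4-cyanophenyl in place of 2-methoxyphenyl gives a 20-fold lower number from compound 1 to compound 4 (1.29 log units; beyond the scatter), the first readable step that lies beyond the scatter. Compound 2 is a limit and sets only a floor for its step, so the methyl change shows no such effect: the limit of > 100000 nM in this assay, at which 1 of the 4 values shown sits.

From the compounds shown here alone, compound 4 exchanges the whole aryl group in one step, and the shares of the nitrile and the methoxy group in that step stay open. Plain phenyl or 4-methoxyphenyl on the same nitrogen would separate them.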